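Removing a trifluoromethyl group from a benzamide tail

A few compounds are considered here, and "the series" means these few. Any claim that something is new, unique, unknown or untested is made for them only; others in the source may bear on it.

Of the compounds shown here, two have been measured in a functional assay on NCI-H460 cells (Homo sapiens) for inhibition, read by sulforhodamine B assay, with a stated time of 48 h; a higher number here means a weaker inhibitor of growth, a lower number a stronger inhibitor of growth. Compound 1 `O=C(Nc1cccc(-n2cc(-c3ccncc3)c(-c3ccc(Cl)c(O)c3)n2)c1)Nc1ccc(Cl)c(Cl)c1` gives 993 nM in this assay. Compound 2 `COc1cc(-c2nn(-c3cccc(NC(=O)c4cccc(C(F)(F)F)c4)c3)cc2-c2ccncc2)ccc1Cl` gives 1450 nM in this assay, the higher of the two numbers, although its gap to compound 1 lies within the usual scatter, so the two cannot be told apart on these data.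

Compound 3 `COc1cc(-c2nn(-c3cccc(NC(=O)c4ccccc4)c3)cc2-c2ccncc2)ccc1Cl` remains to be measured in this assay. It differs from compound 2 by a single change: hydrogen in place of trifluoromethyl on an aromatic carbon. Among the measured compounds shown here, no measured pair shows this change, so there is nothing to read the size of the step from. The expectation is a step from compound 2 to compound 3 of a 1.7-fold higher number from compound 2 to compound 3 (0.24 log units; within the scatter) in this assay, towards a somewhat higher number, close to the edge of the scatter. Compound 3 is therefore estimated at 2500 nM in this assay, with a range from 1000 nM to 6500 nM.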

Compound 3, concentration for 50% growth inhibition: 394 nM
Compound 3: the middle estimate sits 6.3-fold (0.80 log units) above what was measured; measured number below the stated range.
By their numbers in this assay, from the lowest: compound 3; then compounds 1 and 2 (each within the scatter of the next).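

In this assay, among the compounds shown here, replacing the 3-(trifluoromethyl)phenyl of the benzamide tail with phenyl gives a 3.7-fold lower number from compound 2 to compound 3 (0.57 log units; beyond the scatter), a modest step but the first single change in these compounds that can be read. It shows that trifluoromethyl is not required at this position for growth inhibition in these cells, since the compound with hydrogen on that aromatic carbon gives the lower number. Nothing available explains the size or direction of this step.

On these data alone, whether another small group on the same aromatic carbon, such as fluorine, chlorine, methoxy or an amine, would match hydrogen remains open. As far as these compounds go, the step also rests on a single pair, so it is unknown whether removing a substituent would have a similar effect on the tail of compound 1.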